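From 3-fluorophenyl to 2-bromophenyl on the shared core

This account rests on a few compounds, and the source may have more. Where it says the series, first, only, none or still open, it means among the compounds named here.

In an ADME assay on BHK cells (Mesocricetus auratus) for cytotoxicity, read by MTT assay, with a stated time of 96 h (a higher number here means that more compound is tolerated, a lower number that less compound is tolerated), compound 1 (`FC(F)(F)c1cccc(NC(=S)Nc2ccccc2)c1`) gives 41000 nM and compound 2 (`Fc1cccc(NC(=S)Nc2cccc(C(F)(F)F)c2)c1`) gives 9400 nM, the lower of the two numbers. Among the measured compounds shown here, the only measured step, fluoro in place of hydrogen on an aromatic carbon, is modest: a 4.4-fold lower number from compound 1 to compound 2 (0.64 log units; beyond the scatter). Compound 3 (`FC(F)(F)c1cccc(NC(=S)Nc2ccccc2Br)c1`) has 2-bromophenyl in place of 3-fluorophenyl on an amide-type nitrogen. Here one halogen replaces another, and no measured step covers bromo, so the change expected in this assay stays within the scatter, a 1.2-fold higher number from compound 2 to compound 3 (0.07 log units; within the scatter). For compound 3 the estimated value is 11000 nM, with an expected range of 3500 nM to 35000 nM.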

Compound 3, half-maximal cytotoxic concentration: 59000 nM
Compound 3: middle estimate off by 5.4-fold (0.73 log units), on the low side, and the stated range ends below it.
By their numbers in this assay, from the lowest: compound 2; then compounds 1 and 3 (each within the scatter of the next).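

In this assay, 2-bromophenyl in place of 3-fluorophenyl on an amide-type nitrogen is a step beyond the scatter (a 6.3-fold higher number from compound 2 to compound 3 (0.80 log units; beyond the scatter)), so the lower number of compound 2 does not carry over to every halogen-bearing phenyl at this place. The step that adds only a bromo stays within the scatter (a 1.4-fold higher number from compound 1 to compound 3 (0.16 log units; within the scatter)), which leaves compound 2 apart from both compound 1 and compound 3. No evidence on the cause of these differences is at hand.

The compounds shown do not separate the change of halogen from the change of its place on the ring. As far as these compounds go, how a methoxy group or an amine on that ring would compare also remains open.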